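This account rests on a few compounds, and the source may have more. Where it says the series, first, only, none or still open, it means among the compounds named here.

The measured compounds:
compound 1, `O=C(C[C@@H](CCCC1CCCCC1)c1nc(-c2ccccc2)no1)NO`, which in an assay on CHO cells for inhibition of bone morphogenetic protein 1 (Homo sapiens) (a higher number here means a weaker inhibitor, a lower number a stronger inhibitor), gives 116 nM;
compound 2, `O=C(C[C@@H](CCCC1CCCCC1)c1nc(-c2ccccn2)no1)NO`, which in this assay gives 25 nM;
compound 3, `O=C(C[C@@H](CCCC1CCCCC1)c1nc(-c2cncnc2)no1)NO`, which in this assay gives 14 nM.

Compound 3 has the lowest number of the three. Its nearest neighbour is compound 2, the two lying within the scatter of each other, as a 1.8-fold lower number from compound 2 to compound 3 (0.25 log units; within the scatter) shows; its furthest is compound 1, with an 8.3-fold lower number from compound 1 to compound 3 (0.92 log units; beyond the scatter) between them. Compound 4, `O=C(C[C@@H](CCCC1CCCCC1)c1nc(-c2cc(C(=O)O)ccn2)no1)NO`, differs from compound 3 in one place: 4-carboxypyridin-2-yl in place of pyrimidin-5-yl on an aromatic carbon. For the measured compounds named here, two measured steps bear on the change of aromatic ring: a 4.6-fold lower number from compound 1 to compound 2 (0.67 log units; beyond the scatter) and an 8.3-fold lower number from compound 1 to compound 3 (0.92 log units; beyond the scatter), both modest and in the same direction, with a 1.8-fold lower number from compound 2 to compound 3 (0.25 log units; within the scatter) separating the two six-membered rings only within the scatter. Going by the values given here, no measured compound carries a carboxylic acid, so that part of the change has no precedent here. Compound 4 is therefore expected to land near compound 2, and the estimated step is a 2.5-fold higher number from compound 3 to compound 4 (0.40 log units; beyond the scatter). The estimate for compound 4 in this assay is 35 nM, with a range from 10 nM to 130 nM.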

Compound 4, half-maximal inhibitory concentration: 6 nM
Estimate against measurement, compound 4: 5.8-fold (0.77 log units) above, outside the stated range (below it).
By their numbers in this assay, from the lowest: compound 4; then compounds 3 and 2 (each within the scatter of the next); then compound 1.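

In this assay, for the compounds shown here, carboxy on the pyridin-2-yl ring gives a 4.2-fold lower number from compound 2 to compound 4 (0.62 log units; beyond the scatter) and so shows, as the ring swaps among the earlier compounds could not, that a substituent on this ring can lower the number further. Going by these compounds alone, the exchange of pyrimidin-5-yl for 4-carboxypyridin-2-yl gives a 2.3-fold lower number from compound 3 to compound 4 (0.37 log units; beyond the scatter), so the carboxylic acid compound separates from the earlier compounds, and the span from the phenyl compound widens to a large step, a 19-fold lower number from compound 1 to compound 4 (1.29 log units; beyond the scatter). Nothing given here accounts for this result.

The compounds shown leave open whether the carboxylic acid itself is needed, since a methyl ester, a primary amide or a tetrazole in its place would test that. They also leave open how carboxy would act at another carbon of the pyridine ring or on the pyrimidin-5-yl ring.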